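The source may hold more compounds than are shown below. What is called first, only, known or untested is meant among the compounds shown, and "the series" means these compounds.

Compound 1 `COc1ccc(/C=C(/SCc2ccc(F)cc2)C(=O)c2ccc(Cl)cc2)c(OC)c1OC` and compound 2 `COc1ccc(/C=C(\C(=O)c2ccc(Cl)cc2)S(=O)(=O)Cc2ccc(Cl)cc2)c(OC)c1OC` differ by one change, ((4-chlorobenzyl)sulfonyl in place of (4-fluorobenzyl)sulfanyl on a double-bonded chain carbon bound to a carbonyl carbon and a double-bonded chain carbon). In a functional assay on DU-145 cells (Homo sapiens) for inhibition, read by trypan blue exclusion, with a stated time of 96 h (on this read-out higher numbers stand for weaker inhibition of growth and lower numbers for stronger inhibition of growth), compound 1 gives 10000 nM, and compound 2 gives 10000 nM; the step of no change at the digits printed from compound 1 to compound 2 (within the scatter). Compound 3 `CN(C)c1ccc(/C=C(/SCc2ccc(F)cc2)C(=O)c2ccc(C(=O)O)cc2)cc1` carries a different core, and the difference between its core and that of compound 1 is not broken down here. In this assay compound 3 gives 10000 nM, level with compound 1 and compound 2 within the scatter. Compound 4 `CN(C)c1ccc(/C=C(\C(=O)c2ccc(C(=O)O)cc2)S(=O)(=O)Cc2ccc(Cl)cc2)cc1` is obtained from compound 3 by (4-chlorobenzyl)sulfonyl in place of (4-fluorobenzyl)sulfanyl on a double-bonded chain carbon bound to a carbonyl carbon and a double-bonded chain carbon, the same change that turned compound 1 into compound 2. Because no change at the digits printed from compound 1 to compound 2 (within the scatter) on the core of compound 1, the step expected for compound 4 in this assay is no change at the digits printed from compound 3 to compound 4 (within the scatter). Compound 4 is therefore estimated to give 10000 nM in this assay, expected to lie between 5000 nM and 20000 nM.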

Compound 4, concentration for 50% growth inhibition: > 100000 nM
Compound 4: only a limit was reported; the forecaster's own chance of this, stated with the estimate: 35%; middle value at least 10-fold (1.00 log units) away from the limit.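

The change gives an at least 10-fold higher number from compound 3 to compound 4 (1.00 log units; beyond the scatter) in this assay, so it does not carry over unchanged from the core of compound 1 to the core of compound 3: the same change on two cores in this assay, no change at the digits printed (within the scatter) from compound 1 to compound 2 and an at least 10-fold higher number (1.00 log units; beyond the scatter) from compound 3 to compound 4, at least 10-fold (1.00 log units) apart, beyond the scatter of two such steps. Going by these compounds, compound 4 gives > 100000 nM, which is a limit of the assay and not a number, so the full size of this step stays unknown: the limit of > 100000 nM in this assay, at which 1 of the 4 values shown sits. These two pairs show that the outcome of this change differs with the core, but they do not show which part of the core decides it.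

On these data alone, it remains open whether a methyl ester in place of the carboxylic acid would give the same step. Also open, as far as these compounds go, is whether a (4-fluorobenzyl)sulfonyl group alone would match the full change.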